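The compounds below may be only part of what the source reports. "The series", "measured", "known", "first", "only" and "open" are said of these compounds alone.

Series of thiophene-methylamines on a shared bicyclic core. Compound 1 `C[C@H]1[C@H](NCc2ccc(C(C)(C)C)s2)C[C@H]2C[C@@H]1C2(C)C` gives 780 nM in an ADME assay on MDCK cells (Canis lupus familiaris) for cytotoxicity, read by microscopy, with a stated time of 48 h (on this read-out higher numbers stand for lower toxicity in this test and lower numbers for higher toxicity in this test), and compound 2 `Cc1ccc(CN[C@@H]2C[C@H]3C[C@@H]([C@H]2C)C3(C)C)s1` gives 780 nM; the step of no change at the digits printed from compound 1 to compound 2 (within the scatter) lies within the scatter. Compound 3 `C[C@H]1[C@H](NCc2cc(Br)cs2)C[C@H]2C[C@@H]1C2(C)C` gives 6250 nM, the highest number of the three, reached by an 8.0-fold higher number from compound 2 to compound 3 (0.90 log units; beyond the scatter). Compound 4 `C[C@H]1[C@H](NCc2ccc(Cl)s2)C[C@H]2C[C@@H]1C2(C)C` differs from compound 3 by 5-chlorothiophen-2-yl in place of 4-bromothiophen-2-yl on a saturated chain carbon bound to an amine nitrogen. Among the compounds with values here, only the step from compound 2 to compound 3 concerns a change on the thiophene ring, and it was modest; the step from compound 1 to compound 2 does not bear on a halogen swap. Compound 4 is therefore expected to fall between the numbers of compound 2 and compound 3, an expected step of a 3.1-fold lower number from compound 3 to compound 4 (0.49 log units; beyond the scatter) downward. Estimate for compound 4: 2000 nM, range 700 nM to 7000 nM.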

Compound 4, minimum cytotoxic concentration: 25000 nM
Compound 4: middle estimate off by 13-fold (1.10 log units), on the low side; measured number above the stated range.
By their numbers in this assay, from the lowest: compounds 1 and 2 (each within the scatter of the next); then compound 3; then compound 4.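

In this assay, a halogen on the thiophene does not fix the number: 5-chlorothiophen-2-yl in place of 4-bromothiophen-2-yl still moves it (a 4.0-fold higher number from compound 3 to compound 4 (0.60 log units; beyond the scatter)). Chloro in place of methyl (a 32-fold higher number from compound 2 to compound 4 (1.51 log units; beyond the scatter)) and chloro in place of tert-butyl (a 32-fold higher number from compound 1 to compound 4 (1.51 log units; beyond the scatter)) give large steps, although methyl and tert-butyl themselves did not separate. Nothing available explains these steps.

The step from bromo to chloro changes the halogen and its ring place together, so the two stay unseparated. A 5-bromothiophen-2-yl group would part them, and a nitrile there would show whether halogen matters at all.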